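The source may report more compounds than this note shows. Statements on the series, on what has been measured and on what is new or still open speak of the compounds shown alone.

Measured so far in an ADME assay on microsomes from liver (Homo sapiens) for metabolic stability, tested at 2.5 uM; a lower number here means slower removal, a higher number faster removal of the compound:
Compound 1 `COc1ccc(-c2c(S(=O)(=O)c3cc(F)cc(F)c3)cnc3c(F)cccc23)cc1` gives 2.59 mL/min.
Compound 2 `O=S(=O)(c1cc(Cl)cc(Cl)c1)c1cnc2c(F)cccc2c1-c1cccc(Cl)c1` gives 1.2 mL/min.
Compound 3 `O=S(=O)(c1cc(Cl)cc(Cl)c1)c1cnc2c(F)cccc2c1-c1ccc(Cl)cc1` gives 0.78 mL/min.

Compound 3 sits within the scatter of compound 2, while compound 1 lies beyond the scatter, above both. Going by the values given here, the only single-point step measured, a 1.5-fold lower number from compound 2 to compound 3 (0.19 log units; within the scatter), concerns the position of a chloro group and does not touch the change now in question. Compound 4 `COc1ccc(-c2c(S(=O)(=O)c3cc(Cl)cc(Cl)c3)cnc3c(F)cccc23)cc1` differs from compound 3 by methoxy in place of chloro on an aromatic carbon. Compound 1 carries the same methoxyphenyl group but with a different sulfone, so its value bears only loosely on this step. Among the compounds with values here, with no directly comparable step, the size of the change in this assay is uncertain; a moderate rise is expected, a 2.3-fold higher number from compound 3 to compound 4 (0.36 log units; beyond the scatter), giving compound 4 an estimated 1.8 mL/min (range 0.8 mL/min to 4 mL/min).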

Compound 4, intrinsic clearance in a liver preparation (reported as CLH), per the amount of preparation that the assay uses: 2.11 mL/min
Compound 4: middle estimate off by 1.2-fold (0.07 log units), on the low side; the range from low to high includes it.
By their numbers in this assay, from the lowest: compounds 3, 2, 4 and 1 (each within the scatter of the next, the first and the last beyond it).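

In this assay, going by these compounds alone, 4-methoxyphenyl in place of 4-chlorophenyl gives a 2.7-fold higher number from compound 3 to compound 4 (0.43 log units; beyond the scatter) and is the first change at this position to go beyond the scatter. The same compound gives a 1.8-fold higher number from compound 2 to compound 4 (0.25 log units; within the scatter) against the 3-chlorophenyl analogue, while 3,5-dichlorophenyl in place of 3,5-difluorophenyl on the sulfonyl sulfur gives a 1.2-fold lower number from compound 1 to compound 4 (0.09 log units; within the scatter) with the 4-methoxyphenyl group held constant. No measured evidence accounts for these steps.
On these data alone, whether an amine, a hydroxyl or a longer alkoxy chain at this position would follow methoxy or chloro remains open.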